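Aryl Variation on the Carbon Double-Bonded to Nitrogen

The source may report more compounds than this note shows. Statements on the series, on what has been measured and on what is new or still open speak of the compounds shown alone.

The measured compounds:

compound 1, `COc1cc(-n2nnnc2-c2ccc(OCC3CC(c4cccc(Cl)c4)=NO3)c(N)c2)cc(OC)c1OC`, 2180 nM
compound 2, `COc1ccc(OC)c(C2=NOC(COc3ccc(-c4nnnn4-c4cc(OC)c(OC)c(OC)c4)cc3N)C2)c1`, 3500 nM
compound 3, `COc1ccc(F)c(C2=NOC(COc3ccc(-c4nnnn4-c4cc(OC)c(OC)c(OC)c4)cc3N)C2)c1`, 2830 nM

All three were tested in a functional assay on MDA-MB-231 cells (Homo sapiens) for cytotoxicity, read by MTT assay, with a stated time of 48 h; on this read-out lower numbers stand for stronger inhibition and higher numbers for weaker inhibition. Compound 3 gives 2830 nM, the second highest of the three numbers; its nearest neighbour is compound 2, and the two differ by a 1.2-fold lower number from compound 2 to compound 3 (0.09 log units; within the scatter). Compound 1 lies furthest from it, and that gap, a 1.3-fold higher number from compound 1 to compound 3 (0.11 log units; within the scatter), is also within the scatter. The remaining step, a 1.6-fold higher number from compound 1 to compound 2 (0.21 log units; within the scatter), is likewise within the scatter, so the three aryl groups on the carbon with a double bond to nitrogen have so far given no difference that can be trusted.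

Compound 4, `COc1ccc(C2=NOC(COc3ccc(-c4nnnn4-c4cc(OC)c(OC)c(OC)c4)cc3N)C2)cc1O`, carries a further such change: 3-hydroxy-4-methoxyphenyl in place of 2-fluoro-5-methoxyphenyl on a carbon with a double bond to nitrogen. Going by the values given here, two steps bear on it, a 1.6-fold higher number from compound 1 to compound 2 (0.21 log units; within the scatter) and a 1.3-fold higher number from compound 1 to compound 3 (0.11 log units; within the scatter), both aryl swaps at this carbon, both within the scatter. On that basis the step from compound 3 to compound 4 is expected to be none beyond the scatter, a 1.1-fold higher number from compound 3 to compound 4 (0.03 log units; within the scatter). For compound 4 in this assay the estimated value is 3000 nM, between 1200 nM and 7500 nM.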

Compound 4, half-maximal inhibitory concentration: 3380 nM
Beside the measured number, compound 4's estimate is 1.1-fold (0.05 log units) below it; measured number inside the range.
By their numbers in this assay, from the lowest: compounds 1, 3, 4 and 2 (each within the scatter of the next).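

The 3-hydroxy-4-methoxyphenyl group of compound 4 places a hydroxy group on the aryl ring at this position, which compounds 1, 2 and 3 lack, yet in this assay every comparison stays within the scatter: there is a 1.2-fold higher number from compound 3 to compound 4 (0.08 log units; within the scatter) and a 1.0-fold lower number from compound 2 to compound 4 (0.02 log units; within the scatter) and a 1.6-fold higher number from compound 1 to compound 4 (0.19 log units; within the scatter). Four aryl groups on the carbon with a double bond to nitrogen, carrying chloro, fluoro, methoxy or hydroxy groups, have therefore given no difference that can be trusted. No measurement at hand accounts for this flat result.

The compounds shown leave open whether an amine or a carboxylic acid on this aryl ring, or a cyclohexyl group in its place, would give a step beyond the scatter. They also leave the hydroxy group's own share unresolved, since the aryl group of compound 4 differs from each of the others in more than that one group.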